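A few compounds are considered here, and "the series" means these few. Any claim that something is new, unique, unknown or untested is made for them only; others in the source may bear on it.

Within the data shown here, in a functional assay on Jurkat cells (Homo sapiens) for antiproliferative activity, read by MTT assay, with a stated time of 48 h (on this read-out higher numbers stand for weaker inhibition and lower numbers for stronger inhibition), compound 1 `COC(=O)/C=C/c1ccc2c(c1)C(=O)C(=O)N2C` gives 250 nM as its result, the highest of the three numbers so far and therefore the weakest inhibition. Compound 2 `COC(=O)/C=C/c1ccc2c(c1)C(=O)C(=O)N2Cc1ccccc1` stands at 70 nM and compound 3 `COC(=O)/C=C/c1ccc2c(c1)C(=O)C(=O)N2Cc1ccc(C)cc1` stands at 50 nM on the same scale. Putting phenyl in place of hydrogen on a saturated chain carbon bound to an amide-type nitrogen in a ring gave a 3.6-fold lower number from compound 1 to compound 2 (0.55 log units; beyond the scatter) as its result, and 4-methylphenyl at that carbon gave a 5.0-fold lower number from compound 1 to compound 3 (0.70 log units; beyond the scatter) as its result. Both steps are modest but beyond the scatter. Adding the methyl to the aromatic carbon gave a 1.4-fold lower number from compound 2 to compound 3 (0.15 log units; within the scatter) and this stays within the scatter. Compound 4 `COC(=O)/C=C/c1ccc2c(c1)C(=O)C(=O)N2Cc1ccc(Cl)c(Cl)c1` instead carries 3,4-dichlorophenyl at that carbon (3,4-dichlorophenyl in place of hydrogen on a saturated chain carbon bound to an amide-type nitrogen in a ring). Among the measured compounds shown here, no compound with chlorine has been measured yet, which leaves the size uncertain. Resting on a 3.6-fold lower number from compound 1 to compound 2 (0.55 log units; beyond the scatter) and a 5.0-fold lower number from compound 1 to compound 3 (0.70 log units; beyond the scatter) as precedents, a modest move toward a lower number is expected, estimated as a 5.6-fold lower number from compound 1 to compound 4 (0.74 log units; beyond the scatter) in this assay terms. For compound 4 the expected value is 45 nM within an estimated range from 15 nM to 120 nM as the likely span.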

Compound 4, half-maximal inhibitory concentration: 850 nM
Compound 4: middle estimate off by 19-fold (1.28 log units), on the low side; the measured number lies above the stated range.
By their numbers in this assay, from the lowest: compounds 3 and 2 (each within the scatter of the next); then compound 1; then compound 4.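

In this assay, an aromatic ring on this saturated chain carbon does not always lower the number: 3,4-dichlorophenyl in place of hydrogen gives a 3.4-fold higher number from compound 1 to compound 4 (0.53 log units; beyond the scatter), the opposite direction to phenyl and 4-methylphenyl at the same carbon. Which ring sits here also matters far more than the earlier compounds showed, with 3,4-dichlorophenyl in place of phenyl giving a 12-fold higher number from compound 2 to compound 4 (1.08 log units; beyond the scatter) and in place of 4-methylphenyl giving a 17-fold higher number from compound 3 to compound 4 (1.23 log units; beyond the scatter). Still open, on these data alone, is how 4-chlorophenyl, 3-chlorophenyl or a longer chain carrying the phenyl would fall at this position, and so whether a single chlorine already raises the number. Nothing measured here gives a reason for this reversal.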